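A few compounds are considered here, and "the series" means these few. Any claim that something is new, unique, unknown or untested is made for them only; others in the source may bear on it.

Compound 1, with the structure `COC(=O)C1=CO[C@@H](O[C@@H]2O[C@H](COC(c3ccccc3)(c3ccccc3)c3ccccc3)[C@@H](O)[C@H](O)[C@H]2O)[C@@H]2[C@@H](C)[C@@H](O)C[C@H]12`, is the reference point for this set. In a functional assay on COLO 320 cells (Homo sapiens) for cytotoxicity, read by MTT assay, with a stated time of 4 h (a higher number here means a weaker inhibitor, a lower number a stronger inhibitor), compound 1 gives 0.25 ug/mL. Compound 2, with the structure `COC(=O)C1=CO[C@@H](O[C@@H]2O[C@H](CO)[C@@H](OC(C)=O)[C@H](OC(C)=O)[C@H]2OC(C)=O)[C@@H]2[C@@H](C)[C@@H](OC(C)=O)C[C@H]12`, carries acetyl groups on the hydroxyls that are free in compound 1 and a free hydroxymethyl in place of the large trityl ether, and in this assay compound 2 is reported as "not active" (no number reported), so no single number can be read off for it; it stands only as a compound without measurable activity in this test. Compound 3, with the structure `CCC(=O)OC[C@H]1O[C@@H](O[C@@H]2OC=C(C(=O)OC)[C@H]3C[C@H](OC(C)=O)[C@H](C)[C@@H]23)[C@H](OC(C)=O)[C@@H](OC(C)=O)[C@@H]1OC(C)=O`, keeps all the acetyl groups of compound 2 and differs from it in one place, (propanoyl in place of hydrogen on an oxygen on a saturated carbon). Because compound 2 shows "not active" (no number reported), the change to a propanoyl ester on the primary oxygen is a small addition to an already inactive compound, and the expected step in this assay is none beyond the scatter, with weak activity at best. For compound 3 the estimate in this assay is 50 ug/mL, in a range from 10 ug/mL to 200 ug/mL, with a real chance that only a limit is reported.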

Compound 3, half-maximal inhibitory concentration: 0.85 ug/mL
Compound 3: middle estimate off by 59-fold (1.77 log units), on the high side; measured number below the stated range.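

For the compounds shown here, compound 2 has no number in this assay, so no step from it to compound 3 can be read, even though compound 3 gives 0.85 ug/mL. No evidence is available to explain this result. Still open, going by these compounds, is how much a propanoyl ester on that oxygen changes activity when its partner has a measured number.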